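Swapping bromo for chloro on a bromo-oxindole imine

The compounds below may be only part of what the source reports. "The series", "measured", "known", "first", "only" and "open" are said of these compounds alone.

Measured so far:
compound 1, `CCN(CC)CN1C(=O)/C(=N\c2nc3ccc(C)cc3s2)c2c(Br)cccc21`, 28700 nM
compound 2, `Cc1ccc2nc(/N=C3\C(=O)N(CN(c4ccccc4)c4ccccc4)c4cccc(Br)c43)sc2c1`, 75100 nM
compound 3, `O=C1C(=O)N(CN(c2ccccc2)c2ccccc2)c2cccc(Br)c21`, 51100 nM

All three compounds were tested in a functional assay on MDA-MB-231 cells (Homo sapiens) for cytotoxicity, read by sulforhodamine B assay, with a stated time of 48 h; on this read-out higher numbers stand for weaker inhibition of growth and lower numbers for stronger inhibition of growth. Compound 2 gives the highest of the three numbers. Its gap to compound 3, which gives 51100 nM, lies within the usual scatter of repeated measurements, so these two cannot be told apart on the numbers. Its gap to compound 1, which gives 28700 nM, lies beyond the scatter, so compound 1 is the more potent of that pair.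

Compound 4, `Cc1ccc2nc(/N=C3\C(=O)N(CN(c4ccccc4)c4ccccc4)c4cccc(Cl)c43)sc2c1`, has not yet been measured. It differs from compound 2 in one place: chloro in place of bromo on an aromatic carbon. For the measured compounds named here, no pair of measured compounds here shows the effect of such an exchange, so there is no measured step to lean on. A change of one halogen for another on an aromatic carbon is a small alteration of the molecule, and the expectation for this assay is a step of no more than the usual scatter, in no firm direction. The estimated step from compound 2 to compound 4 is therefore a 1.0-fold lower number from compound 2 to compound 4 (0.00 log units; within the scatter). Compound 4 is expected to give about 75000 nM, within a range from 32000 nM to 175000 nM.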

Compound 4, concentration for 50% growth inhibition: 54000 nM
Compound 4: middle estimate off by 1.4-fold (0.14 log units), on the high side, within the range that was stated.
By their numbers in this assay, from the lowest: compounds 1, 3, 4 and 2 (each within the scatter of the next, the first and the last beyond it).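

In this assay, for the compounds shown here, the exchange of bromo for chloro gives the first measured step at this position (a 1.4-fold lower number from compound 2 to compound 4 (0.14 log units; within the scatter)), and that step lies within the usual scatter of repeated measurements. The earlier compounds shown here all carried bromo, so they could say nothing about the halogen itself; this pair shows that, with the rest of the molecule held the same, chloro and bromo on this aromatic carbon cannot be told apart on the numbers, although a single pair cannot show how general that is. Nothing measured here bears on why the step has this size.

The compounds shown carry only bromo or chloro at this carbon, so what a fluoro, a methoxy group or an amine would do there remains open. As far as these compounds go, it also remains open whether the same exchange would give a step of similar size on compound 1 or compound 3, whose other parts differ from those of compound 2.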